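Compound 3 to compound 4: a chlorophenyl isomer

The source may report more compounds than this note shows. Statements on the series, on what has been measured and on what is new or still open speak of the compounds shown alone.

In a functional assay on MCF7 cells (Homo sapiens) for cytotoxicity, read by sulforhodamine B assay (a lower number here means a stronger inhibitor of growth, a higher number a weaker inhibitor of growth), compound 1 (`CC1=CC[C@@H]([C@@](C)(O)CCCC(C)(C)NC(=S)N/N=C\c2ccc(N(C)C)cc2)CC1`) gives > 100000 nM, which is a limit. Compound 2 (`CC1=CC[C@@H]([C@@](C)(O)CCCC(C)(C)NC(=S)N/N=C\c2ccc([N+](=O)[O-])cc2)CC1`) gives > 100000 nM, also a limit. Compound 3 (`CC1=CC[C@@H]([C@@](C)(O)CCCC(C)(C)NC(=S)N/N=C\c2ccccc2Cl)CC1`) gives > 100000 nM, again only a limit. The series therefore stands at the limit of > 100000 nM in this assay, at which 3 of the 3 values shown sit, and compound 3 has no number to start from.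

Compound 4 (`CC1=CC[C@@H]([C@@](C)(O)CCCC(C)(C)NC(=S)N/N=C\c2ccc(Cl)cc2)CC1`) differs from compound 3 by 4-chlorophenyl in place of 2-chlorophenyl on a carbon with a double bond to nitrogen. The closest measured changes are a step that the two limits leave unreadable from compound 1 to compound 3 and a step that the two limits leave unreadable from compound 2 to compound 3, and neither offers a size to carry over. No step beyond the scatter is expected in this assay. The expected change is a number no higher from compound 3 to compound 4 (the limit leaves the size open). For compound 4 the estimated value is 100000 nM, with an expected range of 50000 nM to 200000 nM.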

Compound 4, concentration for total growth inhibition: 15800 nM
Estimate against measurement, compound 4: 6.3-fold (0.80 log units) above, outside the stated range (below it).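

In this assay, among these compounds, 4-chlorophenyl in place of 2-chlorophenyl gives the first readable number, with an at least 6.3-fold lower number from compound 3 to compound 4 (0.80 log units; beyond the scatter), so where the chloro group sits matters even though the atoms are the same. Chloro on the aromatic carbon also separates from the other two groups, with an at least 6.3-fold lower number from compound 2 to compound 4 (0.80 log units; beyond the scatter) and an at least 6.3-fold lower number from compound 1 to compound 4 (0.80 log units; beyond the scatter). The steps among compound 1, compound 2 and compound 3 cannot be read, as all three values are limits: the limit of > 100000 nM in this assay, at which 3 of the 4 values shown sit.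

As far as these compounds go, whether bromo, methoxy or a carboxylic acid in place of the chloro of compound 4 keeps a readable number stays open. From the compounds shown here alone, the full size of each new step also stays open, since each one starts from a limit.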